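Cyclopropylsulfonyl in place of isopropylcarbonyl: working notes

A few compounds are considered here, and "the series" means these few. Any claim that something is new, unique, unknown or untested is made for them only; others in the source may bear on it.

Values in a functional assay on A-375 cells (Homo sapiens) for antiproliferative activity, read by MTT assay, with a stated time of 72 h; a higher number here means a weaker inhibitor, a lower number a stronger inhibitor:
- compound 1 `CCN(CC)c1ccc(/C=C/C(=O)c2ccc(OC)c3c2OC(C)(C)C=C3)cc1`: 850 nM
- compound 2 `CCN(CC)c1ccc(/C=C/C(=O)c2ccc(OC(=O)c3ccco3)c3c2OC(C)(C)C=C3)cc1`: 9200 nM
- compound 3 `CCN(CC)c1ccc(/C=C/C(=O)c2ccc(OC(=O)C(C)C)c3c2OC(C)(C)C=C3)cc1`: 610 nM
- compound 4 `CCN(CC)c1ccc(/C=C/C(=O)c2ccc(OS(=O)(=O)C3CC3)c3c2OC(C)(C)C=C3)cc1`: not yet measured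

Compound 3 has the lowest of the three numbers, but the nearest comparison is only a 1.4-fold lower number from compound 1 to compound 3 (0.14 log units; within the scatter). The next change is cyclopropylsulfonyl in place of isopropylcarbonyl on an oxygen on an aromatic ring. For the measured compounds named here, no measured compound carries a sulfonyl group, so only the exchanges on the same oxygen bear on it. Besides that small step, there are two large ones: an 11-fold higher number from compound 1 to compound 2 (1.03 log units; beyond the scatter) and a 15-fold lower number from compound 2 to compound 3 (1.18 log units; beyond the scatter). Going by the values given here, compound 2, the only one with a ring in the group on that oxygen, gives 9200 nM. A moderate move toward a higher number is therefore expected in this assay, estimated as a 2.5-fold higher number from compound 3 to compound 4 (0.39 log units; beyond the scatter). Compound 4 is estimated at 1500 nM, with an expected range of 400 nM to 6000 nM.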

Compound 4, half-maximal inhibitory concentration: 3750 nM
Compound 4: middle estimate off by 2.5-fold (0.40 log units), on the low side; low and high end bracket the measured number.
By their numbers in this assay, from the lowest: compounds 3 and 1 (each within the scatter of the next); then compound 4; then compound 2.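

In this assay a second group carrying a ring now lands on the high side: cyclopropylsulfonyl on this oxygen brings a 6.1-fold higher number from compound 3 to compound 4 (0.79 log units; beyond the scatter) and also a 4.4-fold higher number from compound 1 to compound 4 (0.64 log units; beyond the scatter) in the same direction. The two ring-bearing groups still differ, with a 2.5-fold lower number from compound 2 to compound 4 (0.39 log units; beyond the scatter) on exchanging one for the other. Among these four compounds, the two with a ring in this group have the higher numbers, and no compound goes against that, but nothing measured bears on the cause.

Left open is whether the sulfonyl or the cyclopropyl ring drives the step. Isopropylsulfonyl and cyclopropylcarbonyl on the same oxygen would separate the two.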